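Amine acylation step in a melanocortin receptor 4 series

The source may report more compounds than this note shows. Statements on the series, on what has been measured and on what is new or still open speak of the compounds shown alone.

Measured so far:
compound 1 `CC(C)C[C@H](N)c1cc(C(F)(F)F)ccc1N1CCN(C(=O)[C@H]2C[S+]([O-])C[C@@H]2c2ccc(Cl)cc2)CC1`: 120 nM
compound 2 `CC(C)C[C@H](N)c1cc(C(F)(F)F)ccc1N1CCN(C(=O)C2C(=O)OCC2c2ccc(Cl)cc2)CC1`: 260 nM

In an assay on HEK293 cells for displacement of a labelled ligand from Melanocortin receptor 4 (Homo sapiens) (a lower number here means a stronger inhibitor, a higher number a weaker inhibitor), compound 1 gives 120 nM, the lowest of the two numbers shown. Compound 2 gives 260 nM, a gap from compound 1 that is beyond the scatter. Going by the values given here, no step between the two measured compounds is available, as they differ in more than one place. Compound 3 `CC(C)C[C@H](NC(=O)CCN(C)C)c1cc(C(F)(F)F)ccc1N1CCN(C(=O)[C@H]2C[S+]([O-])C[C@@H]2c2ccc(Cl)cc2)CC1` keeps the core of compound 1 and differs by (2-(dimethylamino)ethyl)carbonyl in place of hydrogen on an amine nitrogen. The expected step of a 3.3-fold higher number from compound 1 to compound 3 (0.52 log units; beyond the scatter) is a loss beyond the scatter; nothing measured here anchors an acylation of this amine. Compound 3 is estimated at 400 nM, with a range of 120 nM to 1500 nM.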

Compound 3, inhibition constant: 230 nM
For compound 3 the middle estimate is 1.7-fold (0.24 log units) above the measured one, and the stated range covers the measured number.
By their numbers in this assay, from the lowest: compounds 1, 3 and 2 (each within the scatter of the next, the first and the last beyond it).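

In this assay, going by these compounds alone, (2-(dimethylamino)ethyl)carbonyl in place of hydrogen on the amine nitrogen gives a 1.9-fold higher number from compound 1 to compound 3 (0.28 log units; within the scatter), the first single-change step. This amine nitrogen can therefore carry an acyl chain with the dimethylamino group without the number moving beyond the scatter, although this rests on one pair. No supporting data explain this result.

Open, as far as these compounds go, is whether a plain acetyl group, a longer chain or a terminal carboxylic acid would stay within the scatter of compound 1. Also open, from the compounds shown here alone, is whether the same acylation would read alike on the core of compound 2.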